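A Chloro Substituent on the Fluorophenyl Ring and Cytotoxicity

The source may report more compounds than this note shows. Statements on the series, on what has been measured and on what is new or still open speak of the compounds shown alone.

The account concerns compound 2 `C[C@]1(CN2CCc3nc(-c4cccc(F)c4)ccc3C2)Cn2cc([N+](=O)[O-])nc2O1` and its chloro analogue. In an ADME assay on Vero cells (Chlorocebus sabaeus) for cytotoxicity, read by MTT assay, with a stated time of 72 h (on this read-out higher numbers stand for lower toxicity in this test and lower numbers for higher toxicity in this test), compound 2 gives > 32 ug/mL, which is a limit of the assay rather than a number. Compound 1 `C[C@]1(CN2CCc3nc(-c4ccc(F)c(F)c4)oc3C2)Cn2cc([N+](=O)[O-])nc2O1` gives in this assay a value of > 32 ug/mL, likewise a limit of the assay. For the measured compounds named here, both results sit at the limit of > 32 ug/mL in this assay, at which 2 of the 2 values shown sit, so compound 2 stands where every value shown stands, and no step between measured compounds can be read from them. Compound 3 `C[C@]1(CN2CCc3nc(-c4cc(F)ccc4Cl)ccc3C2)Cn2cc([N+](=O)[O-])nc2O1` has not yet been measured in this assay. It differs from compound 2 in one place: chloro in place of hydrogen on an aromatic carbon. With nothing measured to suggest a move, no step beyond the usual scatter is expected in either direction, and the result for compound 3 is expected to remain a limit in most repeats. Compound 3 is accordingly estimated at 40 ug/mL, within 20 ug/mL to 80 ug/mL, an expected step that the limit leaves unreadable from compound 2 to compound 3.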

Compound 3, half-maximal cytotoxic concentration: > 32 ug/mL
Compound 3: a limit, no number; the forecaster's own chance of this, stated with the estimate: 75%; the middle value lies beyond the limit too.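

In this assay, for the compounds shown here, compound 3 gives > 32 ug/mL, a limit of the assay and not a number, so no step from compound 2 can be read. The compounds shown leave open how compound 2 and compound 3 would compare in cytotoxicity, because every result stands at one limit: the limit of > 32 ug/mL in this assay, at which 3 of the 3 values shown sit.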